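Nitro for chloro: expected cytotoxicity of compound 3

This account rests on a few compounds, and the source may have more. Where it says the series, first, only, none or still open, it means among the compounds named here.

Within the data shown here, in a functional assay on MCF7 cells (Homo sapiens) for cytotoxicity, read by MTT assay, with a stated time of 72 h (a higher number here means a weaker inhibitor, a lower number a stronger inhibitor), compound 2 `O=C(CSC(=S)N[C@H]1CCOC1=O)Nc1ccc(C(=O)/C=C/c2ccc(Cl)cc2)cc1` gives 20300 nM, the higher of the two numbers known. Compound 1 `O=C(CCl)Nc1ccc(C(=O)/C=C/c2ccc(Cl)cc2)cc1` gives 4100 nM in this assay, and the step of a 5.0-fold higher number from compound 1 to compound 2 (0.69 log units; beyond the scatter) lies beyond the scatter. Compound 3 `O=C(CSC(=S)N[C@H]1CCOC1=O)Nc1ccc(C(=O)/C=C/c2ccc([N+](=O)[O-])cc2)cc1` differs from compound 2 by nitro in place of chloro on an aromatic carbon. Among the measured compounds shown here, no measured step touches that aromatic carbon; the only step known alters the saturated chain carbon, so it does not bear on this change. The writer therefore expects no step beyond the scatter, a 1.0-fold lower number from compound 2 to compound 3 (0.01 log units; within the scatter). For compound 3 the estimate is 20000 nM, with a range from 7000 nM to 60000 nM.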

Compound 3, half-maximal inhibitory concentration: 2670 nM
Compound 3: middle estimate off by 7.5-fold (0.87 log units), on the high side, outside the stated range (below it).
By their numbers in this assay, from the lowest: compounds 3 and 1 (each within the scatter of the next); then compound 2.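

The aromatic carbon that carries chloro in compound 2 proves sensitive to change: in this assay nitro in place of chloro gives a 7.6-fold lower number from compound 2 to compound 3 (0.88 log units; beyond the scatter) and this step lies beyond the scatter. Among these compounds, it is the first measured change at this carbon, and it shows that the 4-chlorophenyl end, not only the saturated chain carbon, affects the number. Nothing available explains the drop. As far as these compounds go, whether an amine or a methoxy group on this carbon would lower the number too remains open, as does whether nitro would give a similar step with the chlorine-bearing chain of compound 1.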